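A tetrazole in place of the oxadiazolone on the side chain

This account rests on a few compounds, and the source may have more. Where it says the series, first, only, none or still open, it means among the compounds named here.

Compound 3 `CC(C)C(Cc1noc(=O)[nH]1)c1ccc(-c2ccc3cccc(F)c3c2)[nH]c1=O` is the weakest-looking member of the measured set: in a functional assay on CHO cells for antagonist activity at prostaglandin E2 receptor EP3 subtype (Homo sapiens), read by cAMP accumulation (a higher number here means a weaker inhibitor, a lower number a stronger inhibitor), compound 3 gives 70 nM, the highest of the three numbers. Compound 1 `CC(C)C(c1ncco1)c1ccc(-c2ccc3cccc(F)c3c2)[nH]c1=O` gives 64 nM, and compound 2 `CC(C)C(c1nnc[nH]1)c1ccc(-c2ccc3cccc(F)c3c2)[nH]c1=O` gives 21 nM. The spread is small; the step is a 1.1-fold higher number from compound 1 to compound 3 (0.04 log units; within the scatter), while a 3.3-fold higher number from compound 2 to compound 3 (0.52 log units; beyond the scatter) and a 3.0-fold lower number from compound 1 to compound 2 (0.48 log units; beyond the scatter) show that exchanging one five-membered heteroaryl ring for another can shift the number modestly in either direction. Compound 4 `CC(C)C(Cc1nnn[nH]1)c1ccc(-c2ccc3cccc(F)c3c2)[nH]c1=O` differs from compound 3 in one place: a group of 5 heavy atoms (1 carbon, 4 nitrogen; one five-membered aromatic ring with 4 hetero atoms) in place of a group of 6 heavy atoms (2 carbon, 2 nitrogen, 2 oxygen; one five-membered aromatic ring with 3 hetero atoms), on a saturated chain carbon, two bonds along the chain from an aromatic carbon. Among the compounds with values here, the only steps that bear on this are the ring exchanges on a saturated chain carbon bound to an aromatic carbon, each of modest size, so a similar-sized change or none beyond the scatter is expected, with the nitrogen-rich ring of compound 2 hinting that the direction, if any, is downward. Compound 4 is therefore estimated at 45 nM, within a range of 15 nM to 150 nM, a step of a 1.6-fold lower number from compound 3 to compound 4 (0.19 log units; within the scatter) that is expected rather than known.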

Compound 4, half-maximal inhibitory concentration: 134 nM
For compound 4 the middle estimate is 3.0-fold (0.47 log units) below the measured one; the range from low to high includes it.
By their numbers in this assay, from the lowest: compound 2; then compounds 1, 3 and 4 (each within the scatter of the next, the first and the last beyond it).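

In this assay, placing 1H-tetrazol-5-yl on a saturated chain carbon, two bonds along the chain from an aromatic carbon, gives a 1.9-fold higher number from compound 3 to compound 4 (0.28 log units; within the scatter), so this ring exchange at this place is not resolved. The (1H-tetrazol-5-yl)methyl group does separate from the rings on the chain carbon itself, with a 6.4-fold higher number from compound 2 to compound 4 (0.80 log units; beyond the scatter) and a 2.1-fold higher number from compound 1 to compound 4 (0.32 log units; beyond the scatter), but each of these steps changes the ring and the chain length together. No supporting measurement is available to explain these differences.

The compounds shown leave open how much of those two steps belongs to the ring and how much to the added chain carbon, since 1H-tetrazol-5-yl directly on the chain carbon is not among them. On these data alone, how a carboxylic acid at this place, or a longer chain carrying the tetrazole, would read also remains open.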